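Swapping a Furan for a Phenol on a Weak Antiproliferative

A few compounds are considered here, and "the series" means these few. Any claim that something is new, unique, unknown or untested is made for them only; others in the source may bear on it.

Compound 1 `CCCSc1nc(NCc2ccco2)c2nc(Nc3ccccc3)sc2n1` was tested in a functional assay on MGC-803 cells (Homo sapiens) for antiproliferative activity, read by MTT assay, with a stated time of 72 h; a higher number here means a weaker inhibitor, a lower number a stronger inhibitor. Compound 1 gives only a limit there, > 64000 nM. Compound 2 `CCCSc1nc(NC2CC2)c2nc(Nc3ccccc3)sc2n1` likewise gives only a limit, > 64000 nM. Compound 3 `CCCCc1ccc(Nc2nc(SCCC)nc3sc(Nc4ccccc4)nc23)cc1` gives a number, 17400 nM. Both limits sit at the same point (the limit of > 64000 nM in this assay, at which 2 of the 3 values shown sit), so a step that the two limits leave unreadable from compound 1 to compound 2 cannot be read, while an at least 3.6-fold lower number from compound 1 to compound 3 (0.56 log units; beyond the scatter) and an at least 3.6-fold lower number from compound 2 to compound 3 (0.56 log units; beyond the scatter) show that 4-butylphenyl on the ring nitrogen brings a lower number. Compound 4 `CCCSc1nc(NCc2ccc(O)cc2)c2nc(Nc3ccccc3)sc2n1` differs from compound 1 by 4-hydroxyphenyl in place of furan-2-yl on a saturated chain carbon bound to a nitrogen on an aromatic ring, so the new ring still sits on the saturated chain carbon. Going by the values given here, no measured step matches this change; the nearest, an at least 3.6-fold lower number from compound 1 to compound 3 (0.56 log units; beyond the scatter), puts the ring on the nitrogen itself. Compound 4 is therefore expected near 50000 nM, between 15000 nM and 150000 nM. That estimated step, an at least 1.2-fold lower number from compound 1 to compound 4 (0.10 log units; that floor lies within the scatter), is expected to stay within the scatter, with a limit again likely.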

Compound 4, half-maximal inhibitory concentration: 21900 nM
Compound 4: the middle estimate sits 2.3-fold (0.36 log units) above what was measured, and the stated range covers the measured number.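

In this assay, 4-hydroxyphenyl in place of furan-2-yl on the saturated chain carbon gives an at least 2.9-fold lower number from compound 1 to compound 4 (0.46 log units; beyond the scatter), and 4-hydroxybenzyl in place of cyclopropyl gives an at least 2.9-fold lower number from compound 2 to compound 4 (0.46 log units; beyond the scatter). A lower number therefore does not require the ring to sit directly on the nitrogen, and 4-hydroxybenzyl cannot be told apart from 4-butylphenyl, with a 1.3-fold higher number from compound 3 to compound 4 (0.10 log units; within the scatter). The first two steps are only floors, set by a limit of the assay: the limit of > 64000 nM in this assay, at which 2 of the 4 values shown sit.

From the compounds shown here alone, whether the hydroxyl matters, or only the change of ring, stays open. A plain benzyl, 4-methoxybenzyl or 4-aminobenzyl on the same nitrogen would help separate the two.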